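Swapping the Aryl Group on a Coumarin Chalcone

The source may report more compounds than this note shows. Statements on the series, on what has been measured and on what is new or still open speak of the compounds shown alone.

Compound 1, `COc1ccc(/C=C/C(=O)c2cc3ccc(OCc4cccc(OC)c4)cc3oc2=O)cc1`: > 100000 nM
Compound 2, `COc1cccc(/C=C/C(=O)c2cc3cc(OCc4ccccc4)ccc3oc2=O)c1OC`: 21300 nM

In a functional assay on MCF7 cells (Homo sapiens) for cytotoxicity, read by MTT assay, with a stated time of 72 h (a higher number here means a weaker inhibitor, a lower number a stronger inhibitor), compound 1 reaches only a limit, > 100000 nM, so its potency is not pinned to a number. For the measured compounds named here, this is the limit of > 100000 nM in this assay, at which 1 of the 2 values shown sits, and it is the only firm fact about compound 1 here. Compound 2, which shares the core and the double-bonded chain, gives 21300 nM in this assay, a measured number rather than a limit.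

Compound 3, `COc1cccc(COc2ccc3cc(C(=O)/C=C/c4cccc(OC)c4OC)c(=O)oc3c2)c1`, has not yet been measured. It differs from compound 1 in one spot: 2,3-dimethoxyphenyl in place of 4-methoxyphenyl on a double-bonded chain carbon bound to a double-bonded chain carbon. Compound 2 carries that same 2,3-dimethoxyphenyl group and was measurable, so compound 3 is expected to land in a similar region rather than at the limit. Compound 3 is therefore estimated at 40000 nM, likely between 15000 nM and 100000 nM. This implies an expected step of an at least 2.5-fold lower number from compound 1 to compound 3 (0.39 log units; beyond the scatter), toward stronger inhibition.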

Compound 3, half-maximal inhibitory concentration: 35100 nM
Estimate against measurement, compound 3: 1.1-fold (0.06 log units) above, within the range that was stated.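

For the compounds shown here, compound 3 gives the first comparison here between two compounds that differ in one place. In this assay, 2,3-dimethoxyphenyl in place of 4-methoxyphenyl on a double-bonded chain carbon bound to a double-bonded chain carbon gives an at least 2.8-fold lower number from compound 1 to compound 3 (0.45 log units; beyond the scatter), so the aryl group at this spot does change the read-out, toward stronger inhibition. The true size of this step stays unknown, because compound 1 stands at a limit and not at a number: the limit of > 100000 nM in this assay, at which 1 of the 3 values shown sits.

These compounds cannot tell whether the change depends on having both methoxy groups or on where they sit on the ring. They also leave open how a phenyl ring carrying an amine or a carboxylic acid would behave at this same carbon.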